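The source may hold more compounds than are shown below. What is called first, only, known or untested is meant among the compounds shown, and "the series" means these compounds.

Working notes on the series. Compound 1 `O=S(=O)(Nc1ccc(-c2nc3ccccc3o2)cc1)c1ccccc1Cl` and compound 2 `Cc1ccccc1S(=O)(=O)Nc1ccc(-c2nc3ccccc3o2)cc1` share one core and differ in a single group. In an assay on cells for inhibition of HSP60/HSP10 (Homo sapiens), with a stated time of 60 min (on this read-out higher numbers stand for weaker inhibition and lower numbers for stronger inhibition), compound 1 gives > 100000 nM, which is a limit of the assay and not a number. In this assay compound 2 gives 85000 nM, the only number shown so far, the other entry being (the limit of > 100000 nM in this assay, at which 1 of the 2 values shown sits). The step of an at least 1.1-fold lower number from compound 1 to compound 2 (0.07 log units; that floor lies within the scatter) lies within the scatter. Compound 3 `O=S(=O)(Nc1ccc(-c2nc3ccccc3o2)cc1)c1ccccc1C(F)(F)F` carries trifluoromethyl in place of methyl on an aromatic carbon. Among the measured compounds shown here, no measured step covers this exact change, and the single step available is within the scatter, so no shift beyond the scatter is expected, a 1.1-fold higher number from compound 2 to compound 3 (0.05 log units; within the scatter). Compound 3 is therefore estimated near 95000 nM, in the range 40000 nM to 200000 nM, with a real chance of only a limit.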

Compound 3, half-maximal inhibitory concentration: 74000 nM
For compound 3 the middle estimate is 1.3-fold (0.11 log units) above the measured one; the measured number falls inside the stated range.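

In this assay, trifluoromethyl in place of methyl on an aromatic carbon, ortho to a large group, gives a 1.1-fold lower number from compound 2 to compound 3 (0.06 log units; within the scatter), so this change of group does not move the number beyond the scatter. Against chloro, the reading is an at least 1.3-fold lower number from compound 1 to compound 3 (0.13 log units; that floor lies within the scatter), and this is only a floor. Compound 1 is a limit of the assay and not a number: the limit of > 100000 nM in this assay, at which 1 of the 3 values shown sits.

On these data alone, what an amine, a carboxylic acid or a longer chain would do at this position stays open. Also open, as far as these compounds go, is whether any change on the shared core moves the number beyond the scatter.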